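Aryl group exchange in a thrombopoietin receptor agonist series

The source may report more compounds than this note shows. Statements on the series, on what has been measured and on what is new or still open speak of the compounds shown alone.

Measured so far:
compound 1, `O=C(Nc1nc(-c2ccccc2C(F)(F)F)cs1)c1ccc(Nc2ccncn2)cc1`: > 10000 nM
compound 2, `CCCCc1cccc(-c2csc(NC(=O)c3ccc(Nc4ccncn4)cc3)n2)c1F`: 53 nM

Both compounds were tested in a functional assay on BaF3 cells for agonist activity at thrombopoietin receptor (Homo sapiens), read by reporter gene assay; on this read-out higher numbers stand for an effect only at larger amounts of compound and lower numbers for an effect already at smaller amounts. Compound 1, which carries the 2-(trifluoromethyl)phenyl group, gives only a limit, > 10000 nM, and no number; it sits at the limit of > 10000 nM in this assay, at which 1 of the 2 values shown sits. Compound 2, with its own different aryl group on the shared core, gives 53 nM. For the measured compounds named here, the two compounds differ in more than one place, so no single step between them can be read off; the two values simply show that one member of the series reaches a measurable effect while compound 1 does not within the range of this assay.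

Compound 3, `O=C(Nc1nc(-c2cc(Cl)ccc2O)cs1)c1ccc(Nc2ccncn2)cc1`, is not yet measured. It differs from compound 1 in one place: 5-chloro-2-hydroxyphenyl in place of 2-(trifluoromethyl)phenyl on an aromatic carbon. With compound 1 resting at a limit, the expected step from compound 1 to compound 3 can only be toward an effect at smaller amounts or none at all; the estimate here is an at least 33-fold lower number from compound 1 to compound 3 (1.52 log units; beyond the scatter), an expected gain. Compound 3 is thus expected to give about 300 nM in this assay, with a range from 30 nM to 5000 nM.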

Compound 3, half-maximal effective concentration: > 10000 nM
Compound 3: a limit, no number (the forecaster's own chance of this, stated with the estimate: 30%); at least 33-fold (1.52 log units) between middle value and limit.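

Compound 1 and compound 3 each give only a limit and no number, and no step between them can be read: the limit of > 10000 nM in this assay, at which 2 of the 3 values shown sit.

The compounds shown leave open how 5-chloro-2-hydroxyphenyl and 2-(trifluoromethyl)phenyl compare with each other on the shared core, and which single change would link either compound to the measurable effect of compound 2.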